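The source may hold more compounds than are shown below. What is called first, only, known or untested is meant among the compounds shown, and "the series" means these compounds.

In a functional assay on MCF7 cells (Homo sapiens) for antiproliferative activity, read by WST assay, with a stated time of 3 days (a higher number here means a weaker inhibitor, a lower number a stronger inhibitor), three compounds have been measured and none has yielded a number. Compound 1 (`O=c1cc(I)n([C@@H]2O[C@H](CO)[C@@H](O)[C@H]2O)c(=O)[nH]1`) is reported only as a limit, > 50000 nM. Compound 2 (`CNc1cc(=O)[nH]c(=O)n1[C@@H]1O[C@H](CO)[C@@H](O)[C@H]1O`) is also reported only as a limit, > 50000 nM. For the measured compounds named here, compound 3 (`O=c1[nH]c(=O)n([C@@H]2O[C@H](CO)[C@@H](O)[C@H]2O)c(I)c1F`) likewise stands at a limit, > 50000 nM, so the series so far sits at the limit of > 50000 nM in this assay, at which 3 of the 3 values shown sit.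

Compound 4 (`Nc1c(F)c(=O)[nH]c(=O)n1[C@@H]1O[C@H](CO)[C@@H](O)[C@H]1O`) follows from compound 3 by one change: amino in place of iodo on an aromatic carbon. Going by the values given here, two measured steps bear on it. Methylamino in place of iodo gave a step that the two limits leave unreadable from compound 1 to compound 2, and fluoro in place of hydrogen on an aromatic carbon gave a step that the two limits leave unreadable from compound 1 to compound 3. Neither step has a size that can be carried over, and neither shows a compound leaving the limit. The expected step in this assay is therefore a number no higher from compound 3 to compound 4 (the limit leaves the size open), with no change beyond the scatter anticipated. Compound 4 is estimated at 50000 nM, with an expected range from 15000 nM to 100000 nM.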

Compound 4, half-maximal inhibitory concentration: 1400 nM
For compound 4 the middle estimate is 36-fold (1.55 log units) above the measured one, outside the stated range (below it).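

In this assay, amino in place of iodo, on the aromatic carbon next to the ring nitrogen and ortho to the fluoro group, gives an at least 35-fold lower number from compound 3 to compound 4 (1.55 log units; beyond the scatter). This is the only step in the series with a readable size, as the earlier steps cannot be read, and compound 4 is the only compound shown to leave the limit: the limit of > 50000 nM in this assay, at which 3 of the 4 values shown sit. It shows that this position can affect the read-out, since with the fluoro group in place, amino gives a measured value where iodo gives only a limit.

From the compounds shown here alone, it remains open whether amino would give a measured value with hydrogen in place of the fluoro group. Also open, going by these compounds, is how a methylamino, dimethylamino or hydroxyl group would fare at this position alongside the fluoro group.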